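Swapping chloro for hydrogen on compound 2

The source may hold more compounds than are shown below. What is called first, only, known or untested is meant among the compounds shown, and "the series" means these compounds.

In an in vivo ADME assay on the whole organism (strain Sprague-Dawley) for pharmacokinetics, with Rattus norvegicus as the target (on this read-out lower numbers stand for lower oral bioavailability and higher numbers for higher oral bioavailability), compound 1 `CN[C@@H](C)c1ccc(N2CC[C@H](NS(=O)(=O)c3ccc4cc(Cl)ccc4c3)C2=O)c(F)c1` gives > 10% as a limit, not a number. Compound 2 `O=C1[C@@H](NS(=O)(=O)c2ccc3c(Cl)c[nH]c3c2)CCN1c1ccc2c(c1)CCNC2` gives < 1% in this assay, and this too is a limit, not a number. Compound 3 `O=C1[C@@H](NS(=O)(=O)c2ccc3cc[nH]c3c2)CCN1c1ccc2c(c1)CCNC2` has hydrogen in place of chloro on an aromatic carbon, two ring bonds from the ring nitrogen (hydrogen in place of chloro on an aromatic carbon). Within the data shown here, no measured pair shows this change, so no shift beyond the usual scatter is expected, in either direction. The expected step is a number at least 1 percentage points higher from compound 2 to compound 3 (that floor lies within the scatter) and stays within that scatter. Compound 3 is estimated at 2% with an expected range from 0% to 10% in all.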

Compound 3, oral bioavailability: < 1%
Compound 3: a limit, no number; the forecaster's own chance of this, stated with the estimate: 50%; at least 1 percentage points between middle value and limit.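

Compound 2 and compound 3 each give only a limit, not a number, so no step can be read between them: the limit of < 1% in this assay, at which 2 of the 3 values shown sit.

As far as these compounds go, whether hydrogen in place of chloro changes oral bioavailability at all remains open.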